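Adding chloro to the pyridin-2-yl group of compound 3

The source may report more compounds than this note shows. Statements on the series, on what has been measured and on what is new or still open speak of the compounds shown alone.

In an ADME assay on L02 cells (Homo sapiens) for inhibition, read by CCK-8 assay, with a stated time of 48 h (on this read-out higher numbers stand for weaker inhibition of growth and lower numbers for stronger inhibition of growth), three compounds share one core and differ in the group on a nitrogen. Compound 1 `Cc1ccccc1Nc1nc(NC2CCCCC2)ncc1Cl` reads > 100000 nM, which is a limit of the assay. Compound 2 `Cc1ccccc1Nc1nc(NCc2ccccc2)ncc1Cl` reads > 100000 nM, which is also a limit. Among the measured compounds shown here, compound 3 `Cc1ccccc1Nc1nc(Nc2ccccn2)ncc1Cl` gives 6150 nM, the only actual number in the set.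

The data show a step that the two limits leave unreadable from compound 1 to compound 2. Pyridin-2-yl in place of cyclohexyl gives an at least 16-fold lower number from compound 1 to compound 3 (1.21 log units; beyond the scatter), and pyridin-2-yl in place of benzyl gives an at least 16-fold lower number from compound 2 to compound 3 (1.21 log units; beyond the scatter). Both of these large steps exchange the whole group on the nitrogen.

Compound 4 `Cc1ccccc1Nc1nc(Nc2cc(Cl)ccn2)ncc1Cl` differs from compound 3 by chloro in place of hydrogen on an aromatic carbon, opposite the ring nitrogen, turning pyridin-2-yl into 4-chloropyridin-2-yl. For the measured compounds named here, no measured step makes a change this small, and none adds a group to the pyridin-2-yl ring, which leaves the size of this step poorly defined. The large steps to compound 3 do not carry over to it. The expected change is modest and leans towards a lower number, and it may stay within the scatter: a 1.5-fold lower number from compound 3 to compound 4 (0.19 log units; within the scatter). For compound 4 the estimate is 4000 nM, with an expected range from 1500 nM to 10000 nM.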

Compound 4, concentration for 50% growth inhibition: 41500 nM
Beside the measured number, compound 4's estimate is 10-fold (1.02 log units) below it, and the stated range ends below it.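

In this assay, the pyridin-2-yl group turns out to respond to a single added atom: chloro in place of hydrogen on an aromatic carbon, opposite the ring nitrogen, gives a 6.7-fold higher number from compound 3 to compound 4 (0.83 log units; beyond the scatter), which means weaker inhibition of growth, and the earlier exchanges of the whole group on the nitrogen could not show this about one position on the ring. The change gives back part of the difference that separated compound 3 from the other two compounds, but not all of it, since 4-chloropyridin-2-yl still shows an at least 2.4-fold lower number from compound 2 to compound 4 (0.38 log units; beyond the scatter) and an at least 2.4-fold lower number from compound 1 to compound 4 (0.38 log units; beyond the scatter). These two steps are bounds and not sizes, since each starts from a limit of the assay: the limit of > 100000 nM in this assay, at which 2 of the 4 values shown sit.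

The compounds shown leave open whether this rise belongs to chloro itself or would also follow from another group on the same carbon, such as fluoro, methyl or methoxy. They also leave open how chloro, or an amine or a carboxylic acid, would read on the other carbons of the pyridin-2-yl ring.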